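The source may hold more compounds than are shown below. What is called first, only, known or untested is meant among the compounds shown, and "the series" means these compounds.

Compound 1 `OC[C@H]1O[C@@H](n2cnc3c(COc4ccccc4)ncnc32)[C@H](O)[C@@H]1O` carries a phenoxy group on a saturated chain carbon bound to an aromatic carbon of the shared core. In a functional assay on Huh-7 cells (Homo sapiens) for cytotoxicity, read by MTT assay, with a stated time of 3 days (a higher number here means that more compound is tolerated, a lower number that less compound is tolerated), compound 1 gives > 100000 nM, which is a limit of the assay and not a number. Compound 2 `OC[C@H]1O[C@@H](n2cnc3c(CSc4ccccn4)ncnc32)[C@H](O)[C@@H]1O` and compound 3 `O=c1ccn(Cc2ncnc3c2ncn3[C@@H]2O[C@H](CO)[C@@H](O)[C@H]2O)cc1` are close relatives. In this assay compound 2 gives > 100000 nM, also a limit. In this assay compound 3 gives > 100000 nM, a limit as well. All three sit at the limit of > 100000 nM in this assay, at which 3 of the 3 values shown sit, so the steps a step that the two limits leave unreadable from compound 1 to compound 2, a step that the two limits leave unreadable from compound 1 to compound 3 and a step that the two limits leave unreadable from compound 2 to compound 3 have no readable size. Compound 4 `CSCc1ncnc2c1ncn2[C@@H]1O[C@H](CO)[C@@H](O)[C@H]1O` differs from compound 1 by methylsulfanyl in place of phenoxy on a saturated chain carbon bound to an aromatic carbon. With no readable step to build on, the expected step is a step that the limit leaves unreadable from compound 1 to compound 4. Compound 4 is therefore estimated at 200000 nM, with a range from 50000 nM to 800000 nM, most probably again reported as a limit.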

Compound 4, half-maximal cytotoxic concentration: > 100000 nM
Compound 4: a limit, no number; the forecaster's own chance of this, stated with the estimate: 85%; the middle value lies beyond the limit too.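

Compound 4 ends at the same limit as compound 1, compound 2 and compound 3, so no step among them can be read: the limit of > 100000 nM in this assay, at which 4 of the 4 values shown sit.

From the compounds shown here alone, whether any of these groups changes how much compound is tolerated in this assay remains open.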